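The compounds below may be only part of what the source reports. "The series", "measured", "known", "first", "only" and "open" are said of these compounds alone.

Three compounds share one core and differ only in the ring that hangs from an oxygen on a saturated carbon. Compound 1 has the structure `CCC(COc1ccccc1Cl)OC(=O)NCc1ccccc1`. In an assay for inhibition of zeta-carotene desaturase, chloroplastic/chromoplastic (Capsicum annuum), using a Dixon plot, with a stated time of 8 h (on this read-out lower numbers stand for stronger inhibition and higher numbers for weaker inhibition), compound 1 gives > 100000 nM, which is a limit of the assay rather than a number. Compound 2, `CCC(COc1cccc(F)c1)OC(=O)NCc1ccccc1`, gives in this assay the limit > 100000 nM. Compound 3, `CCC(COc1cccc(C)c1)OC(=O)NCc1ccccc1`, gives in this assay the limit > 100000 nM. Compound 3 therefore stands where the other two stand, a picture summed up by the limit of > 100000 nM in this assay, at which 3 of the 3 values shown sit. The three comparisons read a step that the two limits leave unreadable from compound 1 to compound 2, a step that the two limits leave unreadable from compound 1 to compound 3 and a step that the two limits leave unreadable from compound 2 to compound 3; none of them yields a size or a direction.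

Compound 4, `CCC(COc1cccc(NC(C)=O)c1)OC(=O)NCc1ccccc1`, has not yet been measured. Its change from compound 3 is acetamido in place of methyl on an aromatic carbon. With every measured value in this assay a limit, no step can be read that bears on this swap, so the expectation is simply that compound 4 most likely sits at the limit again. The step this estimate implies is expected to be a number no higher from compound 3 to compound 4 (the limit leaves the size open). For compound 4 the estimated value in this assay is 100000 nM, within a range from 30000 nM to 300000 nM.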

Compound 4, half-maximal inhibitory concentration: > 100000 nM
Compound 4 gave a limit, no number; the forecaster's own chance of this, stated with the estimate: 80%; the middle value lies on the limit itself.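

Compound 4, like compound 2 and compound 3, gives only a limit in this assay, so neither step to compound 4 can be read. The compounds shown leave open how strongly any of them inhibits the enzyme, and whether any change to the ring would give a real number: the limit of > 100000 nM in this assay, at which 4 of the 4 values shown sit.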